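A few compounds are considered here, and "the series" means these few. Any claim that something is new, unique, unknown or untested is made for them only; others in the source may bear on it.

Compound 1 `Cc1ccc(Nc2nc(N)nc(COc3ccc4c(C)cc(=O)oc4c3)n2)cc1C` gives 210 nM in an assay on COS-7 cells for agonist activity at Free fatty acid receptor 1 (Homo sapiens), read by scintillation counting and inositol phosphate accumulation, with a stated time of 90 min; on this read-out lower numbers stand for an effect already at smaller amounts and higher numbers for an effect only at larger amounts of compound.
Compound 2 `Cc1ccc(Nc2nc(N)nc(COc3cc(N4CCCC4=O)ccc3F)n2)cc1Cl` gives 33100 nM in this assay.

Both compounds share the same core and differ only in the part carried by the ether oxygen. Of the two numbers recorded, compound 2 stands at the higher end: its value in this assay lies far above that of compound 1, a gap that is well beyond the usual scatter of repeated measurements.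

Compound 3 `Cc1ccc(Nc2nc(N)nc(COc3cc(N4CCCC4=O)ccc3C(F)(F)F)n2)cc1Cl` is the next compound. It is built from compound 2 by a single change: trifluoromethyl in place of fluoro on an aromatic carbon. Among the measured compounds shown here, no step between two measured compounds follows this exact change, so there is no direct precedent for its size or direction. For the measured compounds named here, with only one weak starting point and no comparable pair, the expectation for the step from compound 2 to compound 3 in this assay is a small one, a 1.7-fold lower number from compound 2 to compound 3 (0.22 log units; within the scatter), that may well fall within the scatter.

Compound 3 is therefore expected to give about 20000 nM in this assay, most likely somewhere between 4000 nM and 80000 nM.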

Compound 3, half-maximal effective concentration: 20100 nM
For compound 3 the middle estimate is 1.0-fold (0.00 log units) below the measured one; the range from low to high includes it.
By their numbers in this assay, from the lowest: compound 1; then compounds 3 and 2 (each within the scatter of the next).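

Replacing fluoro with trifluoromethyl on this aromatic carbon, ortho to a large group and para to a 2-oxopyrrolidin-1-yl group, gives a 1.6-fold lower number from compound 2 to compound 3 (0.22 log units; within the scatter) in this assay, so the two compounds cannot be told apart on this read-out. Among the compounds shown here, this is the first direct look at this position, and it shows that a group of 4 heavy atoms can stand here in place of one of 1 heavy atom without a change that rises above the normal variation between repeated measurements. Nothing available here accounts for this result, and no cause can be assigned to it.

Going by these compounds, with only fluoro and trifluoromethyl to compare, both free of hydrogen-bond donors and acceptors and without net charge, it remains open whether this carbon is insensitive to substitution in general or whether a group of another kind, such as an amine or a carboxylic acid, would shift the number clearly. On these data alone, it is also open whether the same exchange would stay this small without the 2-oxopyrrolidin-1-yl group on the ring.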